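Swapping the amide aryl group for a dichloropyrimidine

The compounds below may be only part of what the source reports. "The series", "measured", "known", "first", "only" and "open" are said of these compounds alone.

This series shares one core and varies only the aryl group on the carbonyl carbon of an amide. Compound 1 `O=C(Nc1cccc(-c2oc3cc(-c4ccc(F)cc4)ccc3c(=O)c2O)c1)c1ccc(F)cc1` carries a 4-fluorophenyl there and in a functional assay on HepG2 cells (Homo sapiens) for antiproliferative activity, read by CCK-8 assay, with a stated time of 72 h (on this read-out higher numbers stand for weaker inhibition and lower numbers for stronger inhibition), compound 1 gives 9280 nM. Compound 2 `COc1cccc(C(=O)Nc2cccc(-c3oc4cc(-c5ccc(F)cc5)ccc4c(=O)c3O)c2)c1` has a 3-methoxyphenyl and in this assay compound 2 gives 9950 nM, a change of a 1.1-fold higher number from compound 1 to compound 2 (0.03 log units; within the scatter). Compound 3 `CCc1ccc(C(=O)Nc2cccc(-c3oc4cc(-c5ccc(F)cc5)ccc4c(=O)c3O)c2)cc1` bears a 4-ethylphenyl, and in this assay compound 3 gives 20600 nM, the highest of the three numbers, reached through a 2.2-fold higher number from compound 1 to compound 3 (0.35 log units; beyond the scatter) and a 2.1-fold higher number from compound 2 to compound 3 (0.32 log units; beyond the scatter).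

Compound 4 `O=C(Nc1cccc(-c2oc3cc(-c4ccc(F)cc4)ccc3c(=O)c2O)c1)c1cnc(Cl)nc1Cl` differs from compound 3 by 2,4-dichloropyrimidin-5-yl in place of 4-ethylphenyl on a carbonyl carbon. Among the measured compounds shown here, no measured pair carries a nitrogen-containing ring at this position, so the only steps that bear on the change are the two aryl swaps ending in compound 3, both modest in size and both leaving the number within a narrow band. On that basis compound 4 is expected to stay close to compounds 1, 2 and 3, with a step of a 1.7-fold lower number from compound 3 to compound 4 (0.23 log units; within the scatter) that is estimated to fall at or only slightly beyond the scatter, more likely downward than upward. The value of compound 4 in this assay is therefore estimated at 12000 nM, with a range from 4000 nM to 40000 nM.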

Compound 4, half-maximal inhibitory concentration: > 100000 nM
Compound 4: no number, only a limit; the forecaster's own chance of this, stated with the estimate: 10%; middle value at least 8.3-fold (0.92 log units) away from the limit.
By their numbers in this assay, from the lowest: compounds 1 and 2 (each within the scatter of the next); then compound 3. At a limit, above all of these: compound 4.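

In this assay compound 4 gives no number, only a limit of the assay: the limit of > 100000 nM in this assay, at which 1 of the 4 values shown sits. Among the compounds shown here, measured against that limit, this position on the carbonyl carbon proves far more sensitive than the earlier compounds could show, with 2,4-dichloropyrimidin-5-yl giving an at least 4.8-fold higher number from compound 3 to compound 4 (0.68 log units; beyond the scatter), an at least 10-fold higher number from compound 2 to compound 4 (1.00 log units; beyond the scatter) and an at least 10-fold higher number from compound 1 to compound 4 (1.03 log units; beyond the scatter), all beyond the small differences seen among the earlier aryl groups. For the compounds shown here, the earlier compounds exchanged only one six-membered aromatic ring of carbon for another, whereas this change brings in a ring with 2 hetero atoms and two chlorines while the count of 8 heavy atoms stays the same as in 4-ethylphenyl, so a matching heavy-atom count alone does not keep the number in the earlier range.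

Compound 4 brings in the ring nitrogens and the chlorines together, so which of them accounts for the change stays open, and a 2,4-dichlorophenyl or an unsubstituted pyrimidin-5-yl on this carbonyl carbon would separate the two. Going by these compounds, how far the value of compound 4 lies past its limit also stays open, so the full size of these steps is unknown.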